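Methyl in Place of Fluoro on the Shared Core

The source may report more compounds than this note shows. Statements on the series, on what has been measured and on what is new or still open speak of the compounds shown alone.

Compound 1 `CCOc1ccc2nc(Nc3nc4ccc(F)cc4s3)sc2c1`: 39000 nM
Compound 2 `Fc1ccc(NC(=S)Nc2nc3ccc(F)cc3s2)cc1`: 34600 nM
Compound 3 `Fc1ccc2nc(NC(=S)Nc3ccccc3)sc2c1`: 46600 nM

In a functional assay on THP-1 cells (Homo sapiens) for cytotoxicity, read by MTT assay, with a stated time of 48 h (on this read-out lower numbers stand for stronger inhibition and higher numbers for weaker inhibition), compound 3 holds the highest of the three numbers, yet the three values lie close together and nothing separates them beyond the scatter. Compound 4 `Cc1ccc2nc(NC(=S)Nc3ccccc3)sc2c1` differs from compound 3 by methyl in place of fluoro on an aromatic carbon. Within the data shown here, the only measured step that bears on this position is a 1.3-fold higher number from compound 2 to compound 3 (0.13 log units; within the scatter), and it stayed within the scatter. No step with a methyl entering has been measured, so the data give no reason to expect movement beyond the scatter. The value of compound 4 is therefore estimated at 45000 nM, with a range from 20000 nM to 100000 nM. This estimate means a step of a 1.0-fold lower number from compound 3 to compound 4 (0.02 log units; within the scatter).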

Compound 4, half-maximal inhibitory concentration: > 50000 nM
Compound 4: no number, only a limit; the forecaster's own chance of this, stated with the estimate: 15%; middle value at least 1.1-fold (0.04 log units) from the limit.
By their numbers in this assay, from the lowest: compounds 2, 1 and 3 (each within the scatter of the next). At a limit, above all of these: compound 4.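

In this assay compound 4 gives > 50000 nM, which is a limit of the assay and not a number. Methyl in place of fluoro thus yields only a floor, an at least 1.0-fold higher number from compound 3 to compound 4 (0.03 log units; that floor lies within the scatter), so the size of the step cannot be read. Among these compounds, this is the first step with methyl entering at this position, and it gives no sign of stronger inhibition on the shared core. As far as these compounds go, whether an amine or a carboxylic acid on this aromatic carbon would bring the number down remains open, as does how far compound 4 lies beyond its limit.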